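The compounds below may be only part of what the source reports. "The series", "measured", "known", "first", "only" and "open" are said of these compounds alone.

Compound 1 `C=CCc1cc(OC)c(OC(C)C(OCCOCCCC)c2ccc(O)c(OC)c2)c(OC)c1` is one of two compounds measured in an assay on HEK293 cells for agonist activity at transient receptor potential cation channel subfamily M member 8 (Homo sapiens), read by fluorescence and calcium flux, with a stated time of 5 min; on this read-out lower numbers stand for an effect already at smaller amounts and higher numbers for an effect only at larger amounts of compound; in this assay compound 1 gives 153 nM, the only number shown for the series. Compound 2 `C=CCc1cc(OC)c(O[C@H](C)[C@@H](OC(C)=O)c2ccc(O)c(OC)c2)c(OC)c1` is the second measured compound; in this assay compound 2 gives > 10000 nM, which is a limit of the assay and not a number. The only further point of reference is the limit of > 10000 nM in this assay, at which 1 of the 2 values shown sits. For the measured compounds named here, no step between two measured compounds that differ in a single place is available, so no measured step can be quoted as a guide.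

Compound 3 `C=CCc1cc(OC)c(OC(C)C(OCC(C)C)c2ccc(O)c(OC)c2)c(OC)c1` is not yet measured. It differs from compound 1 in one place: isopropyl in place of butoxymethyl on a saturated chain carbon bound to an oxygen on a saturated carbon. The shared core and the phenol are kept. Going by the values given here, with no measured step to draw on, the expectation rests on compound 1 alone, whose value 153 nM sets the starting point, and a step from compound 1 to compound 3 of a 2.0-fold higher number from compound 1 to compound 3 (0.29 log units; within the scatter) is expected, towards the weaker side but not far beyond the scatter. For compound 3 in this assay a value of 300 nM is estimated, with a range from 80 nM to 1500 nM.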

Compound 3, half-maximal effective concentration: 138 nM
Compound 3: middle estimate off by 2.2-fold (0.34 log units), on the high side; the measured number falls inside the stated range.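

For the compounds shown here, the pair gives the first measured step at this place: in this assay, isopropyl in place of butoxymethyl on a saturated chain carbon bound to an oxygen on a saturated carbon gives a 1.1-fold lower number from compound 1 to compound 3 (0.04 log units; within the scatter) and so no difference that can be read. The two chains are thus not told apart on this read-out, although the leaving butoxymethyl has 6 heavy atoms and 1 hydrogen-bond acceptor and the entering isopropyl has 3 heavy atoms and 0 hydrogen-bond acceptors; for this pair, neither the butyl end nor the ether oxygen of the 2-butoxyethoxy chain is needed for a value of this order. Nothing measured here bears on why the two chains read alike.

On these data alone, whether the position accepts a chain of another kind, such as a 2-aminoethyl chain with its amine, a carboxylic acid or a longer chain such as octyl, stays open. Compound 2 stands at > 10000 nM, a limit of the assay and not a number, and no single change links it to compound 3.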